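Aryl-amine swap in a cytotoxicity series: compound 4

This account rests on a few compounds, and the source may have more. Where it says the series, first, only, none or still open, it means among the compounds named here.

Of the compounds shown here, three sharing one core have been read in an ADME assay on HEK293 cells (Homo sapiens) for cytotoxicity, read by MTT assay, with a stated time of 48 h; on this read-out higher numbers stand for weaker inhibition and lower numbers for stronger inhibition. Compound 1 `Cc1ccc(S(=O)(=O)/N=C(/CCNC2=CC(=O)c3ccccc3C2=O)Nc2ccccc2[N+](=O)[O-])cc1` gives 69600 nM; compound 2 `Cc1ccc(S(=O)(=O)/N=C(/CCNC2=CC(=O)c3ccccc3C2=O)Nc2ccccc2I)cc1` gives 49400 nM; compound 3 `Cc1ccc(S(=O)(=O)/N=C(/CCNC2=CC(=O)c3ccccc3C2=O)Nc2ccc(Cl)cc2Cl)cc1` gives 41900 nM. The steps between them are small: a 1.4-fold lower number from compound 1 to compound 2 (0.15 log units; within the scatter), a 1.7-fold lower number from compound 1 to compound 3 (0.22 log units; within the scatter) and a 1.2-fold lower number from compound 2 to compound 3 (0.07 log units; within the scatter). Compound 3 thus holds the lowest of the three numbers, but every step reaching it stays within the scatter, so no ordering among the three can be claimed.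

Compound 4 `Cc1ccc(S(=O)(=O)/N=C(/CCNC2=CC(=O)c3ccccc3C2=O)Nc2cc(F)c(F)c(F)c2)cc1` is the next member. The change from compound 3 is 3,4,5-trifluorophenyl in place of 2,4-dichlorophenyl on an amine nitrogen, and at one bond further out it reads as (2,4-dichlorophenyl)amino to (3,4,5-trifluorophenyl)amino.

Among the measured compounds shown here, the steps that bear on this change are those that also exchanged the aryl group on the amine nitrogen: a 1.7-fold lower number from compound 1 to compound 3 (0.22 log units; within the scatter) and a 1.2-fold lower number from compound 2 to compound 3 (0.07 log units; within the scatter). Both sit within the scatter. A third exchange of the same aryl group in this assay is therefore expected to give no step beyond the scatter in either direction, and the expected step is a 1.1-fold higher number from compound 3 to compound 4 (0.03 log units; within the scatter).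

For compound 4 the estimated value in this assay is 45000 nM, with an expected range from 20000 nM to 100000 nM.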

Compound 4, half-maximal inhibitory concentration: 82600 nM
Compound 4: middle estimate off by 1.8-fold (0.26 log units), on the low side, and the stated range covers the measured number.
By their numbers in this assay, from the lowest: compounds 3, 2, 1 and 4 (each within the scatter of the next).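

Notes on the aryl group on the amine nitrogen: in this assay the 3,4,5-trifluorophenyl group extends the exchange to a fourth aryl group, and the three new steps all stay within the scatter: a 2.0-fold higher number from compound 3 to compound 4 (0.29 log units; within the scatter), a 1.7-fold higher number from compound 2 to compound 4 (0.22 log units; within the scatter) and a 1.2-fold higher number from compound 1 to compound 4 (0.07 log units; within the scatter). Across the 2-nitrophenyl, 2-iodophenyl, 2,4-dichlorophenyl and 3,4,5-trifluorophenyl groups, this position therefore still shows no resolved difference, even with three fluorines on the ring in place of a nitro group, an iodine or two chlorines. No measured property of these groups accompanies the numbers, so nothing can be said about what lies behind the steps.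

As far as these compounds go, whether a carboxylic acid or an amine on the phenyl ring, or a plain alkyl chain in place of the aryl group on the amine nitrogen, would give a step beyond the scatter remains open. All four compounds share one core, so these numbers also leave open how a change elsewhere in it, such as at the sulfonyl-bearing tolyl group, would read.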